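From trifluoromethoxy to methoxy in a growth-inhibition series

This account rests on a few compounds, and the source may have more. Where it says the series, first, only, none or still open, it means among the compounds named here.

Measured so far in a functional assay on Gurav cells (Homo sapiens) for inhibition, read by sulforhodamine B assay (on this read-out lower numbers stand for stronger inhibition of growth and higher numbers for weaker inhibition of growth), are three compounds:
- Compound 1 `c1ccc(-c2ccc(-c3ccc(-c4nc5ccccc5[nH]4)cc3)cc2)cc1` gives 100000 nM
- Compound 2 `COc1cc(-c2ccc(-c3ccc(-c4nc5cc(C)ccc5[nH]4)cc3)cc2)cc(OC)c1OC` gives 170 nM
- Compound 3 `FC(F)(F)Oc1ccc(-c2ccc(-c3ccc(-c4nc5ccccc5[nH]4)cc3)cc2)cc1` gives 100000 nM

Compound 3 stands level with compound 1, and the two share the highest number of the three. Compound 2 gives 170 nM and so sits far lower.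

Compound 4 `COc1ccc(-c2ccc(-c3ccc(-c4nc5ccccc5[nH]4)cc3)cc2)cc1` has yet to be measured. Its difference from compound 3 is methyl in place of trifluoromethyl on an oxygen on an aromatic ring and in words it is methyl in place of trifluoromethyl on an oxygen on an aromatic ring, so trifluoromethoxy becomes methoxy.

Among the measured compounds shown here, only one measured step bears directly on this place, namely no change at the digits printed from compound 1 to compound 3 (within the scatter) for trifluoromethoxy in place of hydrogen on an aromatic carbon. For the measured compounds named here, no measured step shows methoxy alone. Compound 2 also carries methoxy groups and gives 170 nM in this assay but it differs from compound 3 in more than one place, which makes it only a weak hint.

A modest move towards a lower number is therefore expected, though no change beyond the scatter remains possible. The expected size is a 2.5-fold lower number from compound 3 to compound 4 (0.40 log units; beyond the scatter) as estimated here. For compound 4 the estimated value is 40000 nM with an expected range from 3000 nM to 100000 nM as the likely span.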

Compound 4, concentration for 50% growth inhibition: 38100 nM
Beside the measured number, compound 4's estimate is 1.0-fold (0.02 log units) above it; measured number inside the range.
By their numbers in this assay, from the lowest: compound 2; then compound 4; then compounds 1 and 3 (each within the scatter of the next).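

In this assay, putting methyl in place of trifluoromethyl on the oxygen gives a 2.6-fold lower number from compound 3 to compound 4 (0.42 log units; beyond the scatter) and provides the first measured sign that the group on this oxygen matters. Set against the compound with only hydrogen at this aromatic carbon, methoxy gives a 2.6-fold lower number from compound 1 to compound 4 (0.42 log units; beyond the scatter) while trifluoromethoxy at the same place gave no change at the digits printed from compound 1 to compound 3 (within the scatter) and so left the number where it was, which means that this place can respond to substitution, though only modestly in this pair. Nothing measured here explains why these two groups behave differently on this oxygen.

As far as these compounds go, it remains open whether a longer chain such as ethoxy on the oxygen, or a hydroxyl or an amine at the same aromatic carbon, would move the number further in either direction. Compound 2 at 170 nM differs from compound 4 in more than one place, so the shown compounds cannot say how much of its much lower number comes from its additional methoxy groups and how much from its extra methyl on the other end of the molecule.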